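The source may report more compounds than this note shows. Statements on the series, on what has been measured and on what is new or still open speak of the compounds shown alone.

Working notes on the series in an ADME assay on MT4 cells (Homo sapiens) for cytotoxicity; on this read-out higher numbers stand for lower toxicity in this test and lower numbers for higher toxicity in this test.

Compound 1 `COc1ccc(-c2nnsc2SCC(=O)Nc2ccccc2Br)cc1` gives only a limit of this assay, > 286000 nM. Compound 2 `COc1ccc(-c2nnsc2SCC(=O)Nc2ccccc2F)cc1` likewise gives only a limit, > 332000 nM. Going by the values given here, compound 3 `O=C(CSc1snnc1-c1ccc(F)cc1F)Nc1ccccc1F` gives the one number of the set, 148000 nM. The change 2,4-difluorophenyl in place of 4-methoxyphenyl on an aromatic carbon makes an at least 2.2-fold lower number from compound 2 to compound 3 (0.35 log units; beyond the scatter). The change bromo in place of fluoro on an aromatic carbon makes a step that the two limits leave unreadable from compound 2 to compound 1, since both ends sit at the limit of > 332000 nM in this assay, at which 1 of the 3 values shown sits, and at the limit of > 286000 nM in this assay, at which 1 of the 3 values shown sits.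

Compound 4 `O=C(CSc1snnc1-c1ccc(F)cc1F)Nc1ccccc1Br` is not yet measured. It differs from compound 3 by bromo in place of fluoro on an aromatic carbon, the same change that separates compound 2 from compound 1, and here the surroundings of the place read the same. Because the earlier step that the two limits leave unreadable from compound 2 to compound 1 carries no size, the step from compound 3 to compound 4 is expected to stay near zero, a 1.1-fold lower number from compound 3 to compound 4 (0.02 log units; within the scatter). For compound 4 the expected value in this assay is 140000 nM, between 65000 nM and 300000 nM.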

Compound 4, half-maximal cytotoxic concentration: 144000 nM
The estimate for compound 4 lay 1.0-fold (0.01 log units) below the measured number; measured number inside the range.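

In this assay, bromo in place of fluoro on the core of compound 3 makes a 1.0-fold lower number from compound 3 to compound 4 (0.01 log units; within the scatter). With 2-bromophenyl held on the other side of the molecule, 2,4-difluorophenyl in place of 4-methoxyphenyl makes an at least 1.9-fold lower number from compound 1 to compound 4 (0.29 log units; that floor lies within the scatter). This change therefore points to a lower number on both cores, but the second floor does not clear the scatter, and no size can be carried from one core to the other: the same change on two cores in this assay, an at least 2.2-fold lower number (0.35 log units; beyond the scatter) from compound 2 to compound 3 and an at least 1.9-fold lower number (0.29 log units; that floor lies within the scatter) from compound 1 to compound 4; the limit leaves it open whether they differ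

On these data alone, it remains open how other groups in place of 4-methoxyphenyl, such as an amine or a carboxylic acid, would read. As far as these compounds go, it also remains open whether nitrile or trifluoromethyl in place of bromo would match the near-identical readings of fluoro and bromo.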